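Swapping an isopentyl for a trifluoromethylphenyl on the core

This account rests on a few compounds, and the source may have more. Where it says the series, first, only, none or still open, it means among the compounds named here.

Compound 1, with structure `COc1cccc(CNCCCNc2ccnc3cc(CCC(C)C)ccc23)c1O`, was tested in a physicochemical assay for solubility, with a stated time of 18 h, at pH 7.4 (a higher number here means a more soluble compound, a lower number a less soluble compound), where compound 1 gives 4200 nM. Compound 2, with structure `COc1ccc(F)cc1CNCCCNc1ccnc2cc(CCC(C)C)ccc12`, is the nearest comparison; in this assay compound 2 gives 4200 nM. Among the compounds with values here, the one measured step, no change at the digits printed from compound 1 to compound 2 (within the scatter), shows that exchanging the group on the saturated chain carbon left solubility where it was, so compound 1 stands level with compound 2.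

Compound 3, with structure `COc1cccc(CNCCCNc2ccnc3cc(-c4ccc(C(F)(F)F)cc4)ccc23)c1O`, differs from compound 1 elsewhere: 4-(trifluoromethyl)phenyl in place of isopentyl on an aromatic carbon. Within the data shown here, no measured step touches this position, so the earlier step gives no guide to its size or direction, and the expectation rests on the structural change alone. A drop in solubility is expected, a 4.2-fold lower number from compound 1 to compound 3 (0.62 log units; beyond the scatter), with wide uncertainty. Compound 3 is estimated at 1000 nM in this assay, within a range from 200 nM to 4500 nM.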

Compound 3, solubility: 32000 nM
The estimate for compound 3 lay 32-fold (1.51 log units) below the measured number, and the stated range ends below it.
By their numbers in this assay, from the lowest: compounds 1 and 2 (each within the scatter of the next); then compound 3.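

This aromatic carbon of the core is a position where a change shows up in this assay: 4-(trifluoromethyl)phenyl in place of isopentyl gives a 7.6-fold higher number from compound 1 to compound 3 (0.88 log units; beyond the scatter), whereas the earlier exchange on the chain carbon gave no change at the digits printed from compound 1 to compound 2 (within the scatter). In this single pair, a group that brings an aromatic ring and more heavy atoms goes with a higher number, so a larger group at this position need not lower it. Nothing measured here gives a reason for the rise.

A plain phenyl or a 4-methoxyphenyl at this carbon would help separate the part played by the ring from that of the trifluoromethyl group. On these data alone, it also remains open whether the exchange on the chain carbon would still leave the number level with 4-(trifluoromethyl)phenyl on the core.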